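The source may report more compounds than this note shows. Statements on the series, on what has been measured and on what is new or still open speak of the compounds shown alone.

In an ADME assay on BJ cells (Homo sapiens), read by MTT assay, with a stated time of 72 h (on this read-out higher numbers stand for weaker inhibition and lower numbers for stronger inhibition), two compounds have been measured so far. Compound 1 `C#Cc1cn([C@@H]2O[C@H](CO)[C@@H](O)[C@H]2O)c2ncnc(N(C)C)c12` gives 410 nM in this assay. Compound 2 `CSc1ncnc2c1c(-c1cccs1)cn2[C@@H]1O[C@H](CO)[C@@H](O)[C@H]1O` gives 96900 nM in this assay, the higher of the two numbers, and its gap to compound 1 lies beyond the usual scatter. Within the data shown here, compounds 1 and 2 differ in two places, so no single-point step between them is recorded.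

Compound 3 `CN(C)c1ncnc2c1c(-c1cccs1)cn2[C@@H]1O[C@H](CO)[C@@H](O)[C@H]1O` has not yet been measured in this assay. It differs from compound 2 in one place: dimethylamino in place of methylsulfanyl on an aromatic carbon. Among the measured compounds shown here, compound 3 thus carries the same dimethylamino group that compound 1 carries, which is the only direct guide available. A step of a 16-fold lower number from compound 2 to compound 3 (1.21 log units; beyond the scatter) toward a lower number is expected, because compound 1 with its dimethylamino group gives 410 nM while compound 2 gives 96900 nM. Compound 3 is therefore estimated at 6000 nM, with a range from 900 nM to 40000 nM.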

Compound 3, half-maximal inhibitory concentration: > 100000 nM
Compound 3 gave a limit, no number; the forecaster's own chance of this, stated with the estimate: 10%; middle value at least 16-fold (1.22 log units) from the limit.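

In this assay, the reading for compound 3 is a limit of the assay and not a number: the limit of > 100000 nM in this assay, at which 1 of the 3 values shown sits. With dimethylamino in place of methylsulfanyl on this aromatic carbon, the expected drop did not appear: the result is an at least 1.0-fold higher number from compound 2 to compound 3 (0.01 log units; that floor lies within the scatter), so the change brought no lower number beside thiophen-2-yl, and its true size cannot be read. Dimethylamino therefore does not give a low number on its own, as thiophen-2-yl in place of ethynyl on an aromatic carbon gives an at least 240-fold higher number from compound 1 to compound 3 (2.38 log units; beyond the scatter).

The compounds shown leave open how methylsulfanyl would read alongside ethynyl, and so whether the group on the six-membered ring matters at all when ethynyl is present. They also leave open whether a methyl group in place of thiophen-2-yl would keep a low number.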